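From carboxy to methylcarbamoyl: compound 2 to compound 4

A few compounds are considered here, and "the series" means these few. Any claim that something is new, unique, unknown or untested is made for them only; others in the source may bear on it.

Measured in a functional assay on KB cells (Homo sapiens) for inhibition, read by sulforhodamine B assay, with a stated time of 72 h; on this read-out lower numbers stand for stronger inhibition of growth and higher numbers for weaker inhibition of growth:
- compound 1 `CCOC(=O)/C=C/c1ccncc1-c1ccc2c(cnn2C)c1`: > 10000 nM (a limit)
- compound 2 `Cn1ncc2cc(-c3cnccc3/C=C/C(=O)O)ccc21`: > 10000 nM (a limit)
- compound 3 `CNC(=O)/C=C/c1ccncc1-c1ccc2[nH]ccc2c1`: > 10000 nM (a limit)

Compound 2 gives only a limit, > 10000 nM, and no exact number. The whole set stands at the limit of > 10000 nM in this assay, at which 3 of the 3 values shown sit. Compound 4 `CNC(=O)/C=C/c1ccncc1-c1ccc2c(cnn2C)c1` differs from compound 2 by methylamino in place of hydroxy on a carbonyl carbon, with methylamino in place of hydroxy on a carbonyl carbon. Among the compounds with values here, the one measured step, a step that the two limits leave unreadable from compound 1 to compound 2, has no readable size. Compound 3 carries the same methylcarbamoyl group on a different core, and its result is also a limit, > 10000 nM. No clear gain is therefore expected in this assay. The expected step is a step that the limit leaves unreadable from compound 2 to compound 4. For compound 4 the estimate is 12000 nM, with an expected range of 5000 nM to 30000 nM.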

Compound 4, concentration for 50% growth inhibition: > 10000 nM
Compound 4 was reported as a limit; the forecaster's own chance of this, stated with the estimate: 85%; the middle value lies beyond the limit too.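

Compound 1, compound 2 and compound 4 are all reported only as limits, so no step among them can be read: the limit of > 10000 nM in this assay, at which 4 of the 4 values shown sit.

The compounds shown leave open how strongly any of them inhibits growth in this assay, and whether ethoxy, hydroxy or methylamino on the carbonyl carbon makes any difference there.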